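The source may hold more compounds than are shown below. What is called first, only, known or untested is meant among the compounds shown, and "the series" means these compounds.

Measured so far in a functional assay on NCI-H23 cells (Homo sapiens) for antiproliferative activity, read by sulforhodamine B assay; on this read-out higher numbers stand for weaker inhibition of growth and lower numbers for stronger inhibition of growth:
- compound 1 `CC(C)(C)CCOc1cccc(O)c1C(=O)/C=C/c1ccc(C(=O)O)cc1`: 4770 nM
- compound 2 `CCCCOc1cccc(O)c1C(=O)/C=C/c1ccc(O)cc1`: > 30000 nM (a limit of the assay, not a number)
- compound 3 `CCC(CC)COc1cccc(O)c1C(=O)/C=C/c1ccc(O)cc1`: 3210 nM

Among the compounds with values here, compound 1 has only one neighbour with a true number, compound 3, and their two values lie within the scatter of each other. Compound 4 `CC(C)(C)CCOc1cccc(O)c1C(=O)/C=C/c1ccc(S(N)(=O)=O)cc1` keeps the chain and the core of compound 1 and changes one group: sulfamoyl in place of carboxy on an aromatic carbon.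

Within the data shown here, no measured step makes this swap. Among the measured compounds shown here, the only step available, an at least 9.3-fold lower number from compound 2 to compound 3 (0.97 log units; beyond the scatter), lies in the chain, so its size cannot be carried over to the new group. Going by these compounds, that size is also open-ended because of the limit of > 30000 nM in this assay, at which 1 of the 3 values shown sits.

The nearest hint is a single pair, not a rule. Compound 1 at 4770 nM and compound 3 at 3210 nM differ both in the chain and in the group at the changing place, yet their values stay within the scatter. In this assay, then, no step beyond the scatter is expected in either direction, though the uncertainty is wide.

The expected step is a 1.4-fold lower number from compound 1 to compound 4 (0.13 log units; within the scatter).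

Compound 4 is estimated at 3500 nM, with an expected range from 1000 nM to 13000 nM.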

Compound 4, concentration for 50% growth inhibition: 2950 nM
Beside the measured number, compound 4's estimate is 1.2-fold (0.07 log units) above it; the measured number falls inside the stated range.
By their numbers in this assay, from the lowest: compounds 4, 3 and 1 (each within the scatter of the next). At a limit, above all of these: compound 2.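

In this assay, the step is a 1.6-fold lower number from compound 1 to compound 4 (0.21 log units; within the scatter), so sulfamoyl in place of carboxy, on an aromatic carbon para to a large group, gives two values that cannot be told apart. Within the data shown here, this is the first reading of that place on its own: compound 1 and compound 3 differ both in the chain and at this place, whereas compound 1 and compound 4 share the chain and the core and differ only in this group. For this one swap, a group with one more heavy atom and one more hydrogen-bond acceptor, and the same count of hydrogen-bond donors, leaves growth inhibition within the usual scatter, though a single pair gives no rule for the position and no reason for the result.

Going by these compounds, whether an amine, a nitrile or a methyl ester at this place would also stay within the scatter remains open, as does whether sulfamoyl behaves the same way on a longer chain. The size of the chain effect also stays open-ended because compound 2 is a limit and not a number: the limit of > 30000 nM in this assay, at which 1 of the 4 values shown sits.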